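The source may report more compounds than this note shows. Statements on the series, on what has been measured and on what is new or still open speak of the compounds shown alone.

Measured compounds in a functional assay on A-431 cells (Homo sapiens) for cytotoxicity, read by MTT assay, with a stated time of 72 h, tested at 10 uM; on this read-out lower numbers stand for less inhibition of growth and higher numbers for more inhibition of growth at the one concentration tested:
compound 1 `N/C(=N\NC(=S)N1CCOCC1)c1ccccn1`: 69.4%
compound 2 `Cc1ccnc(/C(N)=N/NC(=S)N2CCOCC2)c1`: 62%

Notes on the series. Among the compounds with values here, compound 1 and compound 2 share one core and differ only in one substituent; the single measured step, a number 7.4 percentage points lower from compound 1 to compound 2 (within the scatter), is within the scatter, so the two values in this assay cannot be told apart and compound 1 stands on a par with compound 2 rather than apart from it.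

Compound 3 `N/C(=N\NC(=S)N1CCCCC1)c1ccccn1` is not yet measured. Relative to compound 1 the change is piperidin-1-yl in place of morpholin-4-yl on a thiocarbonyl carbon. Within the data shown here, no measured step touches this part of the molecule: the only step known, a number 7.4 percentage points lower from compound 1 to compound 2 (within the scatter), concerns the aromatic ring and says nothing about the ring on the thiocarbonyl carbon. There is therefore no measured basis for expecting a shift in either direction in this assay beyond the scatter, and the step of a number 1.4 percentage points lower from compound 1 to compound 3 (within the scatter) is expected to stay within it, with a wide band of uncertainty around it.

On that basis compound 3 is estimated at 68% in this assay, with an expected range from 50% to 84%.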

Compound 3, percent growth inhibition at one concentration: 68.1%
For compound 3 the middle estimate is 0.1 percentage points below the measured one, within the range that was stated.
By their numbers in this assay, from the lowest: compounds 2, 3 and 1 (each within the scatter of the next).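

In this assay, within the data shown here, the step of a number 1.3 percentage points lower from compound 1 to compound 3 (within the scatter) is the first reading on the ring carried by the thiocarbonyl carbon, and it leaves the two compounds indistinguishable. For this pair, the ring oxygen and the hydrogen-bond acceptor counted for morpholin-4-yl are therefore not needed to retain growth inhibition at the one concentration tested, as piperidin-1-yl, a six-membered non-aromatic ring with 1 hetero atom, stands on a par with the ring with 2 hetero atoms. No supporting data bear on why the exchange leaves the read-out within the scatter.

The compounds shown leave open whether this position accepts anything beyond these two rings, such as an open-chain diethylamino group or a 4-methylpiperazin-1-yl ring with its second ring nitrogen. They also leave open whether piperidin-1-yl and the methyl on the aromatic carbon of compound 2 would behave the same way when carried together on the shared core, and how any of these compounds would compare across a range of concentrations.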